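This account rests on a few compounds, and the source may have more. Where it says the series, first, only, none or still open, it means among the compounds named here.

Of the compounds shown here, three have so far been tested in an ADME assay on microsomes from liver (Mus musculus) for metabolic stability, read by LC-MS, with a stated time of 10 min; a lower number here means that less of the compound is left, a higher number that more of the compound is left. Compound 1 `c1cnc2c(c1)CCC[C@@H]2N(CC1CC1)C[C@H]1Cc2c(cccc2N2CCNCC2)CN1` gives 88.3%, compound 2 `CN(C[C@H]1Cc2c(cccc2N2CCN(C3COC3)CC2)CN1)[C@H]1CCCc2cccnc21` gives 50.8%, and compound 3 `CN(C[C@H]1Cc2c(cccc2N2C[C@@H]3C[C@H]2CN3)CN1)[C@H]1CCCc2cccnc21` gives 36.3%, the lowest of the three. Compound 4 `CN(C[C@H]1Cc2c(cccc2N2CCNCC2)CN1)[C@H]1CCCc2cccnc21` has not yet been measured. It differs from compound 3 in one group, on an aromatic carbon: a group of 6 heavy atoms (4 carbon, 2 nitrogen; one six-membered non-aromatic ring with 2 hetero atoms) in place of a group of 7 heavy atoms (5 carbon, 2 nitrogen; 2 five-membered non-aromatic rings with 1 hetero atom each), on an aromatic carbon. Within the data shown here, only one measured step changes the group at this place, and it shows a number 14.5 percentage points lower from compound 2 to compound 3 (beyond the scatter). The group of compound 2 also contains a six-membered non-aromatic ring with 2 hetero atoms, so this modest step, read backwards, points upward for compound 4. Compound 1 carries piperazin-1-yl as well and gives 88.3%, but it differs elsewhere, which makes it only a loose guide. A modest rise is therefore expected in this assay, resting on very little data. The expected change is a number 18.7 percentage points higher from compound 3 to compound 4 (beyond the scatter). The estimate for compound 4 is 55%, with an expected range from 35% to 78%.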

Compound 4, percent of the compound remaining: 19.9%
For compound 4 the middle estimate is 35.1 percentage points above the measured one; measured number below the stated range.
By their numbers in this assay, from the lowest: compound 4; then compound 3; then compound 2; then compound 1.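

In this assay, piperazin-1-yl in place of the group with 2 five-membered non-aromatic rings gives a number 16.4 percentage points lower from compound 3 to compound 4 (beyond the scatter), so having a six-membered ring with two hetero atoms at this place does not by itself keep more of the compound intact. What sits on that ring matters: hydrogen in place of oxetan-3-yl on the ring amine nitrogen gives a number 30.9 percentage points lower from compound 2 to compound 4 (beyond the scatter). The same piperazin-1-yl can also go with a much higher number, as hydrogen in place of cyclopropyl on the saturated chain carbon gives a number 68.4 percentage points lower from compound 1 to compound 4 (beyond the scatter), so the group's effect here cannot be read apart from the rest of the molecule.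

From the compounds shown here alone, it remains open whether a methyl or an acetyl on the ring nitrogen would raise the number as oxetan-3-yl does. Nothing available explains why any of these steps occurs.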